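The source may report more compounds than this note shows. Statements on the series, on what has been measured and on what is new or still open speak of the compounds shown alone.

Measured compounds in a functional assay on RKOp27 cells (Homo sapiens) for cytotoxicity, read by MTT assay, with a stated time of 3 days; on this read-out higher numbers stand for weaker inhibition and lower numbers for stronger inhibition:
compound 1 `N#Cc1c(Nc2ccccc2)nc(SCc2nc3ccccc3[nH]2)nc1-c1ccccc1` gives 4.9 nM
compound 2 `CCNc1nc(SCc2nc3ccccc3[nH]2)nc(-c2ccccc2)c1C#N` gives 7.35 nM
compound 3 `N#Cc1c(NC(N)=O)nc(SCc2nc3ccccc3[nH]2)nc1-c1ccccc1` gives 2.5 nM

Compound 2 holds the highest number of the three; against compound 1 the gap is within the scatter, a 1.5-fold higher number from compound 1 to compound 2 (0.18 log units; within the scatter), while the step to compound 3 lies beyond it, a 2.9-fold lower number from compound 2 to compound 3 (0.47 log units; beyond the scatter). Compound 4 `N#Cc1c(-c2ccccc2)nc(SCc2nc3ccccc3[nH]2)nc1N1CCNCC1` is not yet measured. It differs from compound 2 by piperazin-1-yl in place of ethylamino on an aromatic carbon. Going by the values given here, the steps that bear on this site are a 1.5-fold higher number from compound 1 to compound 2 (0.18 log units; within the scatter), a 2.0-fold lower number from compound 1 to compound 3 (0.29 log units; within the scatter) and a 2.9-fold lower number from compound 2 to compound 3 (0.47 log units; beyond the scatter): each swaps the group at this position, and none moved the number by more than a modest amount. Among the compounds with values here, no measured pair replaces the amino nitrogen by a ring, so the estimate rests on those small steps alone. The expected step is a 1.1-fold lower number from compound 2 to compound 4 (0.02 log units; within the scatter), not clearly beyond the scatter. Compound 4 is therefore estimated at 7 nM, in the range 2.5 nM to 20 nM.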

Compound 4, half-maximal inhibitory concentration: 5.81 nM
Compound 4: middle estimate off by 1.2-fold (0.08 log units), on the high side, within the range that was stated.
By their numbers in this assay, from the lowest: compounds 3, 1, 4 and 2 (each within the scatter of the next, the first and the last beyond it).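

In this assay the position takes a six-membered non-aromatic ring, piperazin-1-yl, with no step beyond the scatter against ethylamino (a 1.3-fold lower number from compound 2 to compound 4 (0.10 log units; within the scatter)) or anilino (a 1.2-fold higher number from compound 1 to compound 4 (0.07 log units; within the scatter)). Against ureido the same ring gives a modest step beyond the scatter (a 2.3-fold higher number from compound 3 to compound 4 (0.37 log units; beyond the scatter)). Nothing measured explains these steps.

From the compounds shown here alone, whether the second ring nitrogen of piperazin-1-yl matters remains open, and piperidin-1-yl or morpholin-4-yl would test this. Also open, going by these compounds, is whether a carboxylic acid or a longer chain on the ring nitrogen would keep the number in this range.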